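The source may report more compounds than this note shows. Statements on the series, on what has been measured and on what is new or still open speak of the compounds shown alone.

In an ADME assay on MT4 cells (Homo sapiens) for cytotoxicity, read by MTT assay, with a stated time of 4 days (on this read-out lower numbers stand for higher toxicity in this test and higher numbers for lower toxicity in this test), compound 3 `N#Cc1ccc(Nc2nc(Oc3ccc(Cl)cc3Cl)c3ccccc3n2)cc1` gives 32000 nM, the lowest of the three numbers measured. Compound 1 `COc1cc(C#N)cc(OC)c1Oc1nc(Nc2ccc(C#N)cc2)nc2ccccc12` gives 194000 nM and compound 2 `COc1ccc(Oc2nc(Nc3ccc(C#N)cc3)nc3ccccc23)cc1` gives 340000 nM. Compound 4 `Cc1cc(C)c(Oc2nc(Nc3ccc(C#N)cc3)nc3ccccc23)c(C)c1` differs from compound 3 in one place: 2,4,6-trimethylphenyl in place of 2,4-dichlorophenyl on an oxygen on an aromatic ring. Among the measured compounds shown here, the only measured step that bears on it changes the same aryl group, and there it was an 11-fold lower number from compound 2 to compound 3 (1.03 log units; beyond the scatter), so swapping that ring can move the number a lot. For the measured compounds named here, no measured compound carries the 2,4,6-trimethylphenyl group, so its direction is uncertain; the step is expected to be moderate and upward, as a 2.0-fold higher number from compound 3 to compound 4 (0.31 log units; beyond the scatter), because compound 3 gives 32000 nM and the other two aryl groups sit higher. Compound 4 is therefore estimated at 65000 nM, within 20000 nM to 200000 nM.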

Compound 4, half-maximal cytotoxic concentration: > 34000 nM
Compound 4: a limit, no number (the forecaster's own chance of this, stated with the estimate: 5%); the middle value lies beyond the limit too.
By their numbers in this assay, from the lowest: compound 3; then compounds 1 and 2 (each within the scatter of the next).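

In this assay compound 4 gives > 34000 nM, which is a limit of the assay and not a number. The comparison gives only an at least 1.0-fold higher number from compound 3 to compound 4 (0.02 log units; that floor lies within the scatter), so 2,4,6-trimethylphenyl on this oxygen is not shown to differ from 2,4-dichlorophenyl, and the step from compound 2 cannot be read. A third aryl group at this place therefore yields a floor rather than a measured size of change. The compounds shown leave open where compound 4 actually lies, and how an aryl group carrying an amine or a carboxylic acid would read here.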